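The source may hold more compounds than are shown below. What is called first, only, known or untested is meant among the compounds shown, and "the series" means these compounds.

In a functional assay on A549 cells (Homo sapiens) for cytotoxicity, read by MTT assay, with a stated time of 48 h (a higher number here means a weaker inhibitor, a lower number a stronger inhibitor), compound 1 (`CC1(C)CCCC2=CC=C(C=O)CC[C@]21C`) gives 138000 nM, compound 2 (`C=C1CCC[C@]2(C)CCC(c3cn(-c4ccc(OC)cc4)nn3)=CC[C@@]12C`) gives 34700 nM and compound 3 (`C=C1CCC[C@]2(C)CCC(c3cn(-c4ccc(C(C)=O)cc4)nn3)=CC[C@@]12C`) gives 46400 nM. Compound 3 thus sits within the scatter of compound 2, while its number lies beyond the scatter under that of compound 1. Compound 4 (`C=C1CCC[C@]2(C)CCC(c3cn(-c4cccc([N+](=O)[O-])c4)nn3)=CC[C@@]12C`) carries 3-nitrophenyl in place of 4-acetylphenyl on an aromatic nitrogen. Within the data shown here, only one measured step bears on this change: a 1.3-fold higher number from compound 2 to compound 3 (0.13 log units; within the scatter), with acetyl in place of methoxy on an aromatic carbon. Among the measured compounds shown here, no compound with a nitro group has been measured yet, so no step beyond the scatter is expected in this assay. The expected step is a 1.2-fold lower number from compound 3 to compound 4 (0.06 log units; within the scatter). Compound 4 is estimated at 40000 nM, with an expected range of 18000 nM to 90000 nM.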

Compound 4, half-maximal inhibitory concentration: 24700 nM
Estimate against measurement, compound 4: 1.6-fold (0.21 log units) above; measured number inside the range.
By their numbers in this assay, from the lowest: compounds 4, 2 and 3 (each within the scatter of the next); then compound 1.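

In this assay, placing 3-nitrophenyl on the aromatic nitrogen gives a 1.9-fold lower number from compound 3 to compound 4 (0.27 log units; within the scatter) and a 1.4-fold lower number from compound 2 to compound 4 (0.15 log units; within the scatter). Among these compounds, this position has therefore now held a nitro-bearing ring as well as 4-acetylphenyl and 4-methoxyphenyl, with no step among the three beyond the scatter. Nothing measured here accounts for these steps. As far as these compounds go, it remains open whether an amine or a carboxylic acid on this phenyl ring would give a step beyond the scatter. Since 3-nitrophenyl differs from the other two in both its group and that group's place on the ring, those two changes also remain unseparated.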